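The compounds below may be only part of what the source reports. "The series", "measured", "known", "first", "only" and "open" are said of these compounds alone.

Working notes on the series. Compound 1 `CC(O)(COc1cccc(S(F)(F)(F)(F)F)c1)C(=O)Nc1ccc(C(F)(F)F)cc1` serves as the reference; in a functional assay on LNCaP cells (Homo sapiens) for antiproliferative activity, read by propidium iodide staining, with a stated time of 96 h (a lower number here means a stronger inhibitor, a higher number a weaker inhibitor), compound 1 gives 12800 nM. Compound 3 `CC(O)(COc1cccc(C(F)(F)C(F)(F)F)c1)C(=O)Nc1ccc(C(F)(F)F)cc1` differs from compound 1 only by a group of 7 heavy atoms (2 carbon, 5 fluorine; no ring) in place of a group of 6 heavy atoms (5 fluorine, 1 sulfur; no ring), on an aromatic carbon, and in this assay compound 3 gives 3900 nM; the step is a 3.3-fold lower number from compound 1 to compound 3 (0.52 log units; beyond the scatter). Compound 2 `CC(O)(COc1cccc(S(F)(F)(F)(F)F)c1)C(=O)Nc1cc(C(F)(F)F)cc(C(F)(F)F)c1` carries a different core, and how the core of compound 2 differs from the core of compound 1 is not broken down here. In this assay compound 2 gives 3000 nM, a lower number than compound 1 shows, while compound 2 and compound 3 lie within the scatter of each other.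

Compound 4 `CC(O)(COc1cccc(C(F)(F)C(F)(F)F)c1)C(=O)Nc1cc(C(F)(F)F)cc(C(F)(F)F)c1` has not been measured. It differs from compound 2 by a group of 7 heavy atoms (2 carbon, 5 fluorine; no ring) in place of a group of 6 heavy atoms (5 fluorine, 1 sulfur; no ring), on an aromatic carbon, the same change by which compound 3 differs from compound 1: the leaving group, the entering group and the place are described in the same words. Among the measured compounds shown here, only one measured instance of this change exists, so its transfer onto the core of compound 2 is untested, and the two cores are not compared in detail. In this assay the expected step is a 3.0-fold lower number from compound 2 to compound 4 (0.48 log units; beyond the scatter), set beside the measured 3.3-fold lower number from compound 1 to compound 3 (0.52 log units; beyond the scatter), and rests on that single precedent. Compound 4 is therefore estimated at 1000 nM in this assay. With one precedent only, compound 4 is expected to fall between 400 nM and 2500 nM.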

Compound 4, half-maximal inhibitory concentration: 4400 nM
Estimate against measurement, compound 4: 4.4-fold (0.64 log units) below; measured number outside the range, above it.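

On the core of compound 2, the exchange of the group of 6 heavy atoms for 1,1,2,2,2-pentafluoroethyl gives a 1.5-fold higher number from compound 2 to compound 4 (0.17 log units; within the scatter) in this assay, so the clear gain seen on the core of compound 1 does not reappear here. The change therefore does not carry over from one core to the other with the same size in this series: the same change on two cores in this assay, a 3.3-fold lower number (0.52 log units; beyond the scatter) from compound 1 to compound 3 and a 1.5-fold higher number (0.17 log units; within the scatter) from compound 2 to compound 4, 4.8-fold (0.68 log units) apart, beyond the scatter of two such steps

These two pairs show that the result of this change depends on the core among the compounds shown, but they do not show which feature of the two cores is responsible, and they give no basis for predicting the step on any further core.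

The compounds shown leave open how a nitrile or a longer fluorinated chain such as heptafluoropropyl would read at the same aromatic carbon in this assay, on either core. They also leave open whether the same dependence on the core would hold with an amine in place of the hydroxyl group of the shared chain.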